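Swapping dimethylamino for isopropyl on a bromo-methoxy aryl ring

A few compounds are considered here, and "the series" means these few. Any claim that something is new, unique, unknown or untested is made for them only; others in the source may bear on it.

This piece follows three measured compounds and one that is still waiting for its number. Compound 1 `CCN(c1nc(C)cc(C)n1)c1c(Br)cc(N(C)C)cc1OC` is tested in an assay on isolated protein for binding affinity to corticotropin-releasing factor receptor 1 (Homo sapiens) (on this read-out lower numbers stand for stronger inhibition and higher numbers for weaker inhibition), and gives 5 nM. Compound 2 `CCCCN(CC)c1nc(C)nc(N(CC)c2ccc(OC(F)(F)F)cc2Br)n1` gives 5 nM in this assay; compound 1 sits level with it at the digits shown, and the two together hold the lowest numbers of the three. Compound 3 `CCN(c1nc(C)cc(C)n1)c1ccc(N(C)C)cc1C(F)(F)F` gives 68 nM in this assay, a markedly higher number than compound 1, and the gap between them lies beyond the scatter.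

Compound 4 `CCN(c1nc(C)cc(C)n1)c1c(Br)cc(C(C)C)cc1OC` shares the core of compound 1 and differs from it in one place: isopropyl in place of dimethylamino on an aromatic carbon.

Going by the values given here, no pair of measured compounds shows this same exchange, so the size of the step has to be guessed from what the table offers. Compound 2 carries no dimethylamino group at all and still gives 5 nM, so strong binding in this assay does not appear to depend on that group alone. The step from compound 1 to compound 4 is therefore expected to be small, most likely a modest rise, a 2.0-fold higher number from compound 1 to compound 4 (0.30 log units; within the scatter). Compound 4 is estimated to give 10 nM, with a range from 3 nM to 40 nM.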

Compound 4, inhibition constant: 26 nM
Compound 4: the middle estimate sits 2.6-fold (0.41 log units) below what was measured; low and high end bracket the measured number.
By their numbers in this assay, from the lowest: compounds 1 and 2 (each within the scatter of the next); then compound 4; then compound 3.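

In this assay, going by these compounds alone, putting isopropyl in place of dimethylamino on this aromatic carbon gives a 5.2-fold higher number from compound 1 to compound 4 (0.72 log units; beyond the scatter), the first direct reading of what a change at this position does while the rest of the molecule stays fixed. The two groups have the same count of heavy atoms, 3 each, but the exchange replaces a nitrogen with a carbon and takes away 1 hydrogen-bond acceptor, so the position is sensitive to more than the number of heavy atoms placed there; even so, the step is modest, and compound 4 still binds with a value of 26 nM in this assay. Nothing in the data at hand explains why the number rises with this exchange.

Going by these compounds, a single exchange cannot show whether nitrogen itself matters at this position, so it remains open how a plain amine or a morpholine ring would compare with dimethylamino, and how a methyl group or a longer chain would compare with isopropyl. On these data alone, it is also open whether the same exchange would produce a step of similar size on the core of compound 3, which carries trifluoromethyl and lacks the bromo and methoxy groups.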